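The source may hold more compounds than are shown below. What is called first, only, known or untested is meant among the compounds shown, and "the series" means these compounds.

For the measured compounds named here, in a functional assay on HCT-116 cells (Homo sapiens) for inhibition, read by MTT assay, with a stated time of 48 h (a lower number here means a stronger inhibitor, a higher number a weaker inhibitor), compound 1 (`COc1ccc(CNc2cc(OC)c(OC)c(OC)c2)cc1Cl`) gives 41700 nM, the highest of the three numbers so far, while compound 3 (`C/C=C/C(=O)N(Cc1ccc(OC)c(Cl)c1)c1cc(OC)c(OC)c(OC)c1`) gives 1420 nM and compound 2 (`COc1ccc(CN(C(=O)CCl)c2cc(OC)c(OC)c(OC)c2)cc1O`) gives the lowest at 250 nM in this set. Going by the values given here, the one measured step (a 29-fold lower number from compound 1 to compound 3 (1.47 log units; beyond the scatter)) is large, but it falls on the nitrogen, not on the aromatic carbon that changes here. Compound 4 (`COc1ccc(CNc2cc(OC)c(OC)c(OC)c2)cc1N`) carries amino in place of chloro on an aromatic carbon, ortho to a methoxy group (amino in place of chloro on an aromatic carbon). Among the compounds with values here, no measured step covers this change, so in this assay only a moderate move toward a lower number is expected (a 2.8-fold lower number from compound 1 to compound 4 (0.44 log units; beyond the scatter)). Compound 4 is estimated at 15000 nM (3000 nM to 60000 nM).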

Compound 4, half-maximal inhibitory concentration: 8270 nM
The estimate for compound 4 lay 1.8-fold (0.26 log units) above the measured number; the range from low to high includes it.
By their numbers in this assay, from the lowest: compound 2; then compound 3; then compound 4; then compound 1.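

In this assay, the aromatic carbon ortho to a methoxy group now has a measured step of its own: amino in place of chloro gives a 5.0-fold lower number from compound 1 to compound 4 (0.70 log units; beyond the scatter) and so moves the number beyond the scatter. This modest step is smaller than the large one on the nitrogen, a 29-fold lower number from compound 1 to compound 3 (1.47 log units; beyond the scatter), so the nitrogen change remains the bigger of the two measured from compound 1. Nothing available explains the shift. The compounds shown leave open how a fluoro or methyl group would read at this carbon, and whether the amino step holds when the nitrogen carries the (prop-1-en-1-yl)carbonyl of compound 3.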